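A few compounds are considered here, and "the series" means these few. Any claim that something is new, unique, unknown or untested is made for them only; others in the source may bear on it.

Working notes on the series. Compound 1 `Cc1c(C(=O)NCc2cccc(O)c2)cnn1-c1ccc(Cl)cc1`, compound 2 `Cc1c(C(=O)NCc2cccc(N)c2)cnn1-c1ccc(Cl)cc1` and compound 3 `Cc1c(C(=O)NCc2ccccn2)cnn1-c1ccc(Cl)cc1` share one core and differ only in the group on the saturated chain carbon bound to the amide-type nitrogen. In a functional assay on cells for antagonist activity at C-C chemokine receptor type 1 (Homo sapiens), read by FLIPR and calcium flux (a lower number here means a stronger inhibitor, a higher number a weaker inhibitor), compound 1 gives > 3000 nM, which is a limit of the assay and not a number. Compound 2 gives > 3000 nM in this assay, again only a limit. Compound 3 gives > 3000 nM in this assay, also a limit. All three values sit at the limit of > 3000 nM in this assay, at which 3 of the 3 values shown sit, so compound 3 has no number that would set it apart from the other two. The steps a step that the two limits leave unreadable from compound 1 to compound 2, a step that the two limits leave unreadable from compound 1 to compound 3 and a step that the two limits leave unreadable from compound 2 to compound 3 are all unreadable; every value involved is a limit.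

Compound 4 `Cc1c(C(=O)NCc2cccnc2)cnn1-c1ccc(Cl)cc1` is not yet measured. It differs from compound 3 by pyridin-3-yl in place of pyridin-2-yl on a saturated chain carbon bound to an amide-type nitrogen. Among the compounds with values here, no measured step bears on this change with a readable size; what the three measured compounds show is that moving among 3-hydroxyphenyl, 3-aminophenyl and pyridin-2-yl at this place never brought a value under the limit. The step from compound 3 to compound 4 is therefore expected to be a step that the limit leaves unreadable from compound 3 to compound 4, with no readable direction. Compound 4 is expected to give about 6000 nM in this assay, within 2000 nM to 20000 nM, most likely again reported only as a limit.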

Compound 4, half-maximal inhibitory concentration: > 3000 nM
Compound 4: only a limit was reported; the forecaster's own chance of this, stated with the estimate: 80%; the middle value does not contradict the limit.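

Compound 4 gives > 3000 nM in this assay, a limit of the assay and not a number. The steps from compound 1, compound 2 and compound 3 to compound 4 therefore cannot be read, and all four compounds sit at one limit: the limit of > 3000 nM in this assay, at which 4 of the 4 values shown sit.

The compounds shown leave open whether any group on the saturated chain carbon bound to an amide-type nitrogen gives a measurable value.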